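This account rests on a few compounds, and the source may have more. Where it says the series, first, only, none or still open, it means among the compounds named here.

Measured compounds:
Compound 1, `Brc1cccc2c1nnn2CC1CCC1`, gives 12 mL/min/g.
Compound 2, `Brc1cccc2c1nnn2CC1CC1`, gives 0.6 mL/min/g.

Both compounds were run in an ADME assay on microsomes from liver (Rattus norvegicus, strain Wistar) for metabolic stability, tested at 2.5 uM; on this read-out lower numbers stand for slow clearance and higher numbers for fast clearance. Among the two numbers known, compound 2 stands lowest; its nearest neighbour is compound 1, and the step of a 20-fold lower number from compound 1 to compound 2 (1.30 log units; beyond the scatter) separates them, a change made by cyclopropyl in place of cyclobutyl on a saturated chain carbon bound to an aromatic nitrogen.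

Compound 3, `CCCCn1nnc2c(Br)cccc21`, is not yet measured. It differs from compound 2 by propyl in place of cyclopropyl on a saturated chain carbon bound to an aromatic nitrogen. Going by the values given here, the one measured step that bears on this position is a 20-fold lower number from compound 1 to compound 2 (1.30 log units; beyond the scatter): exchanging one small ring for another at this same carbon moved this assay far beyond the scatter. Replacing the ring with an open propyl chain is a change of a different kind, so the size of the step cannot be read off directly, but the direction is expected to be toward a higher number, since compound 2 already holds the lowest value seen and its step of a 20-fold lower number from compound 1 to compound 2 (1.30 log units; beyond the scatter) shows how sensitive this position is.

Compound 3 is therefore expected to give 4 mL/min/g, within the range 1.2 mL/min/g to 13 mL/min/g, an expected step of a 6.7-fold higher number from compound 2 to compound 3 (0.82 log units; beyond the scatter).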

Compound 3, intrinsic clearance in a liver preparation (reported as CLH), per the amount of preparation that the assay uses: 4.4 mL/min/g
The estimate for compound 3 lay 1.1-fold (0.04 log units) below the measured number; low and high end bracket the measured number.
By their numbers in this assay, from the lowest: compound 2; then compound 3; then compound 1.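

Compound 3 shows that a ring at this position does not by itself give a low number in this assay: a 7.3-fold higher number from compound 2 to compound 3 (0.87 log units; beyond the scatter), yet a 2.7-fold lower number from compound 1 to compound 3 (0.44 log units; beyond the scatter), so the open chain falls inside the range set by the two ring compounds. Cyclopropyl and propyl have the same count of heavy atoms, all of them carbon, so a change at this saturated chain carbon bound to an aromatic nitrogen can move the number beyond the scatter with that count unchanged, and the low number of compound 2 belongs to cyclopropyl alone among the three groups. No measurement at hand explains why the three groups rank in this order.

The three compounds leave open how a longer chain such as pentyl, a branched group such as isobutyl, or a chain carrying an ether oxygen or an amine would compare with these values. From the compounds shown here alone, they also share one core with its bromine unchanged, so whether the same order of cyclopropyl, propyl and cyclobutyl would hold with chlorine or a nitrile in its place remains unknown.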